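The source may report more compounds than this note shows. Statements on the series, on what has been measured and on what is new or still open speak of the compounds shown alone.

Measured in a functional assay on L1210 cells (Mus musculus) for inhibition; on this read-out lower numbers stand for stronger inhibition and higher numbers for weaker inhibition:
- Compound 1 `COc1cccc(/C=C2\Cc3ccccc3C2=O)c1`: 217000 nM
- Compound 2 `O=C1/C(=C/c2cccc([N+](=O)[O-])c2)CCCc2ccccc21`: 48800 nM
- Compound 3 `O=C1CCCCC/C1=C\c1cccc(F)c1`: 382000 nM

Compound 3, at 382000 nM, lies within the usual scatter of compound 1, at 217000 nM. The number for compound 3 is higher than that of compound 2, at 48800 nM, and this gap, which means weaker inhibition for compound 3, goes beyond the scatter.

The next compound, compound 4 `Cc1cccc(/C=C2\CCCCCC2=O)c1`, has methyl in place of fluoro on an aromatic carbon of compound 3 (methyl in place of fluoro on an aromatic carbon). For the measured compounds named here, no two measured compounds differ in only one place, so the data offer no direct measure of this swap. With nothing to suggest a shift, the expectation in this assay is no change beyond the scatter, and compound 4 should stay close to compound 3 at 382000 nM. The expected step, a 1.3-fold lower number from compound 3 to compound 4 (0.10 log units; within the scatter), is therefore small. For compound 4 the estimated value is 300000 nM, with an expected range from 120000 nM to 700000 nM.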

Compound 4, half-maximal inhibitory concentration: 263000 nM
Compound 4: the middle estimate sits 1.1-fold (0.06 log units) above what was measured, within the range that was stated.
By their numbers in this assay, from the lowest: compound 2; then compounds 1, 4 and 3 (each within the scatter of the next).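

For the compounds shown here, compound 3 and compound 4 form the first pair that differs in only one place, so this swap can now be read directly. In this assay, putting methyl in place of fluoro on this aromatic carbon gives a 1.5-fold lower number from compound 3 to compound 4 (0.16 log units; within the scatter), which means that this one exchange of a single heavy atom does not separate the two compounds on this read-out. Nothing available bears on why the two groups read so alike.

Still open, as far as these compounds go, is whether an amine, a carboxylic acid or a longer chain on this same aromatic carbon would move the number beyond the scatter. Also open, from the compounds shown here alone, is whether methyl and fluoro would read as closely on the core of compound 1 or the core of compound 2.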